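Opening the piperidine to an aminopropyl chain

The source may report more compounds than this note shows. Statements on the series, on what has been measured and on what is new or still open speak of the compounds shown alone.

Compound 2, `c1cc([C@H]2CC[C@]3(CC2)OOC2(O3)C3CC4CC(C3)CC2C4)ccc1OCC1CCNCC1`, is one of three compounds on a shared core that were tested in an ADME assay on microsomes from liver (Homo sapiens) for metabolic stability, read by LC-MS, tested at 1 uM; a higher number here means faster removal of the compound, a lower number slower removal. In this assay compound 2 gives < 7 mL.min-1.g-1, which is a limit of the assay rather than a number. Compound 1, `NCCOc1ccc([C@H]2CC[C@]3(CC2)OOC2(O3)C3CC4CC(C3)CC2C4)cc1`, gives < 7 mL.min-1.g-1 in this assay, again a limit. Among the measured compounds shown here, compound 3, `CC1(C)CC(O)(COc2ccc([C@H]3CC[C@]4(CC3)OOC3(O4)C4CC5CC(C4)CC3C5)cc2)CC(C)(C)N1`, is the only one with a read number, giving 14 mL.min-1.g-1 in this assay. Compound 2 therefore stands at the lower edge of what this assay reports, sharing that position with compound 1 (the limit of < 7 mL.min-1.g-1 in this assay, at which 2 of the 3 values shown sit). The step that the two limits leave unreadable from compound 1 to compound 2 cannot be read. The steps of an at least 2.0-fold higher number from compound 2 to compound 3 (0.30 log units; that floor lies within the scatter) and an at least 2.0-fold higher number from compound 1 to compound 3 (0.30 log units; that floor lies within the scatter) place the 4-hydroxy-2,2,6,6-tetramethylpiperidin-4-yl compound higher, though only at a floor within the scatter.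

Compound 4, `NCCCCOc1ccc([C@H]2CC[C@]3(CC2)OOC2(O3)C3CC4CC(C3)CC2C4)cc1`, has not yet been measured. It differs from compound 2 as follows: 3-aminopropyl in place of piperidin-4-yl on a saturated chain carbon bound to an oxygen on an aromatic ring. The step from compound 1 to compound 2 bears most closely on this change, as compound 1 carries aminomethyl and compound 4 carries 3-aminopropyl on the same saturated chain carbon, and that step is unreadable with both ends at the limit. Compound 4 is accordingly expected to show a step that the limit leaves unreadable from compound 2 to compound 4, nothing beyond the scatter. The estimate for compound 4 in this assay is 5 mL.min-1.g-1, between 2 mL.min-1.g-1 and 12 mL.min-1.g-1, most likely reported again as a limit.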

Compound 4, intrinsic clearance in microsomes: < 7 mL.min-1.g-1
Compound 4 ended at the assay's limit; the forecaster's own chance of this, stated with the estimate: 65%; the middle value does not contradict the limit.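

With compound 4, the open 3-aminopropyl chain, which has no ring, joins the piperidin-4-yl of compound 2 and the shorter aminomethyl of compound 1 at the lower edge of this assay, so at this position neither the ring nor the longer chain lifts the result off that edge: the limit of < 7 mL.min-1.g-1 in this assay, at which 3 of the 4 values shown sit. The steps linking compound 4 to compound 2 and to compound 1 cannot be read, and any differences among these three compounds stay hidden behind the limit. Among the compounds shown here, the one readable step is an at least 2.0-fold lower number from compound 3 to compound 4 (0.30 log units; that floor lies within the scatter), which adds no firmer separation than the earlier steps to compound 3 did.

The compounds shown leave open which part of the 4-hydroxy-2,2,6,6-tetramethylpiperidin-4-yl group goes with the only read number in the set, since the hydroxyl and the four methyl groups appear only together, in compound 3. They also leave open whether a tertiary amine such as dimethylamino, or a carboxylic acid in place of the amine, at the end of the same chain would stay at this limit or give a read number.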